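A few compounds are considered here, and "the series" means these few. Any claim that something is new, unique, unknown or untested is made for them only; others in the source may bear on it.

For compound 1 `O=C(CSc1ncccn1)N/N=c1/scc(-c2ccccc2)n1-c1ccccc1`, a functional assay on C6 cells (Rattus norvegicus) for cytotoxicity, read by MTT assay, with a stated time of 24 h (on this read-out higher numbers stand for weaker inhibition and lower numbers for stronger inhibition), gives "not determined" (no result reported), so it offers no number to compare. In this assay, compound 2 `Cn1cnnc1SCC(=O)N/N=c1/scc(-c2ccc(C#N)cc2)n1-c1ccccc1` gives > 200 ug/mL, which is a limit of the assay and not a number. The next structure is compound 3 `Cn1cnnc1SCC(=O)N/N=c1/scc(-c2ccccc2)n1-c1ccccc1`, and the change is small: hydrogen in place of cyano on an aromatic carbon. In words, hydrogen stands in place of cyano on an aromatic carbon, turning 4-cyanophenyl into phenyl. For the measured compounds named here, no measured step shows what this swap does, so in this assay the expected step of a number no higher from compound 2 to compound 3 (the limit leaves the size open) stays within the usual scatter, with no direction favoured. For compound 3 the estimated value is 200 ug/mL, within an expected range of 70 ug/mL to 400 ug/mL.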

Compound 3, half-maximal inhibitory concentration: 68.3 ug/mL
Beside the measured number, compound 3's estimate is 2.9-fold (0.47 log units) above it; measured number below the stated range.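

In this assay, putting hydrogen in place of cyano, which turns 4-cyanophenyl into phenyl, gives an at least 2.9-fold lower number from compound 2 to compound 3 (0.46 log units; beyond the scatter). For the compounds shown here, this is the first sign that this aromatic carbon matters, with the lower number meaning stronger inhibition. The value for compound 2 is a limit of the assay and not a number, so the full size of the step stays open: the limit of > 200 ug/mL in this assay, at which 1 of the 3 values shown sits.

Only cyano and hydrogen appear at this carbon. From the compounds shown here alone, how a methyl group, a chlorine atom or an amine would behave there remains open.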